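A few compounds are considered here, and "the series" means these few. Any claim that something is new, unique, unknown or untested is made for them only; others in the source may bear on it.

Measured compounds:
Compound 1 `CCO/C(O)=C1\C(C)=NC(C)=C(C(=O)OCCCN2C(=O)c3ccccc3S2(=O)=O)C1c1cccc([N+](=O)[O-])c1` gives 1.9 nM in a functional assay (aorta) with Oryctolagus cuniculus as the target; on this read-out lower numbers stand for stronger inhibition and higher numbers for weaker inhibition.
Compound 2 `COCCO/C(O)=C1\C(C)=NC(C)=C(C(=O)OCCCN2C(=O)c3ccccc3S2(=O)=O)C1c1cccc([N+](=O)[O-])c1` gives 6.8 nM in this assay.

Compound 2 stands at the higher of the two numbers, its nearest neighbour being compound 1. Going by the values given here, the only step seen is a 3.6-fold higher number from compound 1 to compound 2 (0.55 log units; beyond the scatter). Compound 3 `CC1=NC(C)=C(C(=O)OCCCN2C(=O)c3ccccc3S2(=O)=O)C(c2cccc([N+](=O)[O-])c2)/C1=C(\O)OCC1CCCO1` differs from compound 2 by oxolan-2-yl in place of methoxymethyl on a saturated chain carbon bound to an oxygen on an unsaturated carbon. Among the compounds with values here, no measured step covers this change directly; the one step available shows that an ether oxygen introduced two bonds along the chain from the ester oxygen cost a modest amount, and compound 3 keeps one ether oxygen in a ring in that region. The change is therefore expected to move the number little, estimated as a 1.4-fold lower number from compound 2 to compound 3 (0.13 log units; within the scatter) in this assay. For compound 3 the expected value is 5 nM, with a range from 1.5 nM to 16 nM.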

Compound 3, half-maximal inhibitory concentration: 10.5 nM
Compound 3: the middle estimate sits 2.1-fold (0.32 log units) below what was measured; measured number inside the range.
By their numbers in this assay, from the lowest: compound 1; then compounds 2 and 3 (each within the scatter of the next).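

Closing the open 2-methoxyethyl group into (oxolan-2-yl)methyl gives a 1.5-fold higher number from compound 2 to compound 3 (0.19 log units; within the scatter) in this assay, so at this place the ring and the open chain cannot be told apart on this read-out. Set against the ethyl group of compound 1, the same ring gives a 5.5-fold higher number from compound 1 to compound 3 (0.74 log units; beyond the scatter), and so both groups carrying an ether oxygen, the open one of compound 2 and the ring of compound 3, stand at higher numbers than compound 1. Nothing available bears on why these numbers fall as they do.

The compounds shown leave open whether the higher numbers go with the ether oxygen or with the longer group as such, a question that a plain butyl group at this place would bear on. From the compounds shown here alone, how an amine or a carboxylic acid at the end of this chain would read also remains open.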